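The source may hold more compounds than are shown below. What is called first, only, known or untested is meant among the compounds shown, and "the series" means these compounds.

Measured so far in an assay on HEK293 cells for displacement of a labelled ligand from 5-hydroxytryptamine receptor 4 (Homo sapiens), read by scintillation counting; on this read-out higher numbers stand for weaker inhibition and lower numbers for stronger inhibition:

Compound 1 `COc1cc(N)c(Cl)cc1C(=O)NC1CCN(CCN2CCCCC2)CC1` gives 251 nM.
Compound 2 `COc1cc(N)c(Cl)cc1C(=O)NC1CCN(CCCCCCCCN2CCCCC2)CC1` gives 3.16 nM.
Compound 3 `COc1cc(N)c(Cl)cc1C(=O)NC1CCN(CCN2CCN(S(C)(=O)=O)CC2)CC1` gives 126 nM.

Compound 2 stands lowest of the three, and the difference between the cores of compound 1 and compound 2 is not broken down here. From compound 1 to compound 3 the change is 4-(methylsulfonyl)piperazin-1-yl in place of piperidin-1-yl on a saturated chain carbon, two bonds along the chain from an amine nitrogen in a ring, and it made a step of a 2.0-fold lower number from compound 1 to compound 3 (0.30 log units; within the scatter).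

Compound 4 `COc1cc(N)c(Cl)cc1C(=O)NC1CCN(CCCCCCCCN2CCN(S(C)(=O)=O)CC2)CC1` has not yet been measured. It differs from compound 2 by 4-(methylsulfonyl)piperazin-1-yl in place of piperidin-1-yl on a saturated chain carbon, eight bonds along the chain from an amine nitrogen in a ring. This is the same kind of change as from compound 1 to compound 3, though the place differs: two bonds along the chain from an amine nitrogen in a ring there, eight bonds along the chain here. Because a 2.0-fold lower number from compound 1 to compound 3 (0.30 log units; within the scatter) was within the scatter, the step in this assay from compound 2 is expected to be small, about a 1.3-fold lower number from compound 2 to compound 4 (0.10 log units; within the scatter). Compound 4 is thus estimated at 2.5 nM, within a range from 0.8 nM to 8 nM.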

Compound 4, inhibition constant: 15.9 nM
For compound 4 the middle estimate is 6.4-fold (0.80 log units) below the measured one; the measured number lies above the stated range.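

On the core of compound 2, 4-(methylsulfonyl)piperazin-1-yl in place of piperidin-1-yl gave a 5.0-fold higher number from compound 2 to compound 4 (0.70 log units; beyond the scatter) in this assay. Set beside the earlier step, the same change did not carry over at the same size from one core to the other: the same change on two cores in this assay, a 2.0-fold lower number (0.30 log units; within the scatter) from compound 1 to compound 3 and a 5.0-fold higher number (0.70 log units; beyond the scatter) from compound 2 to compound 4, 10-fold (1.00 log units) apart, beyond the scatter of two such steps. This rests on one pair of steps on two cores, and it does not show what sets the two cores apart or how the change would run on any other core in the series.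

The compounds shown leave open how the same change would run on a butyl or a hexyl chain. They also leave open whether a morpholine or an acetyl-capped piperazine would follow the same course.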